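This account rests on a few compounds, and the source may have more. Where it says the series, first, only, none or still open, it means among the compounds named here.

Working notes on the series. In an assay on isolated protein for inhibition of malate dehydrogenase, mitochondrial (Sus scrofa), with stated times of 45 min and 30 min (on this read-out lower numbers stand for stronger inhibition and higher numbers for weaker inhibition), compound 1 `O=S(=O)(Nc1ccc(-c2nc3ccccc3o2)cc1)c1ccccc1O` gives only a limit of the assay, > 63000 nM. Compound 3 `CCc1ccc(S(=O)(=O)Nc2ccc(-c3nc4ccccc4o3)cc2)cc1` likewise gives only a limit in this assay, > 63000 nM. Compound 2 `CCc1ccc(S(=O)(=O)Nc2ccc3oc(-c4ccccc4)nc3c2)cc1` also gives only a limit in this assay, > 63000 nM. The change 2-hydroxyphenyl in place of 4-ethylphenyl on a sulfonyl sulfur yields a step that the two limits leave unreadable from compound 3 to compound 1 because both ends sit at the limit of > 63000 nM in this assay, at which 3 of the 3 values shown sit. Compound 4 `O=S(=O)(Nc1ccc2oc(-c3ccccc3)nc2c1)c1ccccc1O` carries the same kind of change on the core of compound 2, (2-hydroxyphenyl in place of 4-ethylphenyl on a sulfonyl sulfur); how the cores of compound 2 and compound 3 differ is not broken down here, and the place of the change reads the same in both cases. The step from compound 2 to compound 4 is expected to be a step that the limit leaves unreadable from compound 2 to compound 4 in this assay, resting on a step that the two limits leave unreadable from compound 3 to compound 1 and on the limits shared by all three measured compounds. Compound 4 is therefore expected to sit near 90000 nM in this assay, between 40000 nM and 250000 nM.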

Compound 4, half-maximal inhibitory concentration: > 63000 nM
Compound 4 was reported as a limit (the forecaster's own chance of this, stated with the estimate: 85%); the middle value is on the limit's open side.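

Compound 2 and compound 4 both stand only as limits, so no new step can be read from this pair: the limit of > 63000 nM in this assay, at which 4 of the 4 values shown sit.

The compounds shown leave open how far either sulfonyl substituent or either core changes inhibition, as none gives a numerical value.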